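The source may hold more compounds than are shown below. What is called first, only, known or untested is meant among the compounds shown, and "the series" means these compounds.

Measured compounds:
`Cc1ccc(Cn2cc(CNC(=O)c3cnc(Nc4ccc(C#N)cc4)cc3Oc3c(C)cc(C)cc3C)nn2)cc1` compound 1, 165000 nM
`CCOC(=O)Cn1cc(CNC(=O)c2cnc(Nc3ccc(C#N)cc3)cc2Oc2c(C)cc(C)cc2C)nn1` compound 2, 9530 nM

In an ADME assay on MT4 cells (Homo sapiens) for cytotoxicity, read by MTT assay, with a stated time of 5 days (a lower number here means that less compound is tolerated, a higher number that more compound is tolerated), compound 2 gives the lowest of the two numbers; the nearest is compound 1, whose number is higher by a 17-fold lower number from compound 1 to compound 2 (1.24 log units; beyond the scatter) read the other way. The unmeasured compound 3, `Cc1cc(C)c(Oc2cc(Nc3ccc(C#N)cc3)ncc2C(=O)NCc2cn(Cc3ccccc3Cl)nn2)c(C)c1`, differs from compound 2 by 2-chlorophenyl in place of ethoxycarbonyl on a saturated chain carbon bound to an aromatic nitrogen. Among the measured compounds shown here, the one measured step that bears on this place, a 17-fold lower number from compound 1 to compound 2 (1.24 log units; beyond the scatter), went the opposite way, from a 4-methylphenyl to the ethoxycarbonyl, and was large and beyond the scatter. Putting an aromatic ring back at this position is therefore expected to raise the number again, by an amount of the same order, though a 2-chlorophenyl is not the same as a 4-methylphenyl and the only pair shown is compound 1 and compound 2. Compound 3 is accordingly estimated at 80000 nM, with a range of 20000 nM to 200000 nM, a step of an 8.4-fold higher number from compound 2 to compound 3 (0.92 log units; beyond the scatter) upward from compound 2.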

Compound 3, half-maximal cytotoxic concentration: >= 188000 nM
Compound 3 ended at the assay's limit (the forecaster's own chance of this, stated with the estimate: 15%); middle value at least 2.3-fold (0.37 log units) from the limit.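

Among the compounds shown here, the low number of compound 2 now stands against a second aromatic group as well as 4-methylphenyl: this assay shows an at least 19-fold higher number from compound 2 to compound 3 (1.29 log units; beyond the scatter), so within these compounds the ethoxycarbonyl is the one group that gives the lower number. The two aromatic groups cannot be put in order, and their comparison reads an at least 1.1-fold higher number from compound 1 to compound 3 (0.05 log units; that floor lies within the scatter). The result for compound 3 is a limit of the assay and not a number: the limit of >= 188000 nM in this assay, at which 1 of the 3 values shown sits.

From the compounds shown here alone, how far the true number of compound 3 lies past that limit stays open, and with it any real difference between 2-chlorophenyl and 4-methylphenyl. Also open, going by these compounds, is whether the lower number belongs to ethoxycarbonyl in particular or would also appear with a carboxylic acid, an amine or a longer chain at this place.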